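Working notes: one side-chain change from compound 2

The compounds below may be only part of what the source reports. "The series", "measured", "known", "first", "only" and "open" are said of these compounds alone.

Measured in an in vitro ADME assay on microsomes (Homo sapiens) for metabolic stability; on this read-out lower numbers stand for a shorter-lived compound and higher numbers for a longer-lived compound:
- compound 1 `Cc1c2c(n3c1CCN(C(=O)[C@H](C)N)CC[C@H](C)Nc1cc-3ccc1C(N)=O)CC(C)(C)CC2=O`: 0.433 h
- compound 2 `CC[C@H](N)C(=O)N1CCc2c(C)c3c(n2-c2ccc(C(N)=O)c(c2)N[C@@H](C)[C@H](C)C1)CC(C)(C)CC3=O`: 0.417 h

Compound 2 gives 0.417 h and compound 1 gives 0.433 h, two values within the scatter of each other. Compound 3 `Cc1c2c(n3c1CCN(C(=O)[C@H](C)O)C[C@@H](C)[C@H](C)Nc1cc-3ccc1C(N)=O)CC(C)(C)CC2=O` has not yet been measured. It carries 1-hydroxyethyl in place of the 1-aminopropyl of compound 2 on a carbonyl carbon (1-hydroxyethyl in place of 1-aminopropyl on a carbonyl carbon). Within the data shown here, no pair of measured compounds differs in one place only, so the data hold no direct precedent for this change. With only compound 2 at 0.417 h as an anchor, no shift beyond the scatter is expected in this assay, and no direction can be favoured. The estimated step is a 1.1-fold higher number from compound 2 to compound 3 (0.03 log units; within the scatter). The value expected for compound 3 is 0.45 h, with an estimated range of 0.22 h to 0.9 h.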

Compound 3, half-life: 0.25 h
For compound 3 the middle estimate is 1.8-fold (0.26 log units) above the measured one; the range from low to high includes it.
By their numbers in this assay, from the lowest: compounds 3, 2 and 1 (each within the scatter of the next).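

In this assay, among these compounds, the exchange gives a 1.7-fold lower number from compound 2 to compound 3 (0.22 log units; within the scatter) and thus provides the first direct one-place comparison. On a carbonyl carbon whose other neighbour is an amide-type nitrogen in a ring, 1-hydroxyethyl in place of 1-aminopropyl leaves the two compounds within the scatter of each other, so this single step does not separate them on half-life. No supporting data bear on why the read-out behaves this way.

From the compounds shown here alone, the exchange alters both the heteroatom and the chain, so the contribution of each remains open, and 1-hydroxypropyl on the same carbonyl carbon would separate the two. Going by these compounds, whether a more different group there, such as a carboxylic acid or a longer chain, moves the half-life beyond the scatter also remains open.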